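The source may hold more compounds than are shown below. What is called first, only, known or untested is meant among the compounds shown, and "the series" means these compounds.

Working notes on the series.

In an assay on brain for binding affinity to Adrenergic receptor alpha-1 (Rattus norvegicus) (on this read-out higher numbers stand for weaker inhibition and lower numbers for stronger inhibition), compound 1 `COc1cc2nc(N3CCN(c4ncccn4)CC3)nc(N)c2cc1OC` gives 0.26 nM. Compound 2 `COc1cc2nc(N3CCN(c4ccncn4)CC3)nc(N)c2cc1OC` gives 0.27 nM in this assay, and compound 3 `COc1cc2nc(N3CCN(c4nccc(N(C)C)n4)CC3)nc(N)c2cc1OC` gives 0.27 nM. Compound 2 stands level with compound 3 at the digits shown, the two together the highest of the three numbers, while its nearest other neighbour is compound 1, with a 1.0-fold higher number from compound 1 to compound 2 (0.02 log units; within the scatter).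

Compound 4 `COc1cc2nc(N3CCN(c4nccc(C)n4)CC3)nc(N)c2cc1OC` has not yet been measured in this assay. It differs from compound 2 in that (4-methylpyrimidin-2-yl in place of pyrimidin-4-yl on an amine nitrogen in a ring).

For the measured compounds named here, three measured steps bear on this change. Swapping the attachment of the ring gave a 1.0-fold higher number from compound 1 to compound 2 (0.02 log units; within the scatter). Adding a dimethylamino group gave a 1.0-fold higher number from compound 1 to compound 3 (0.02 log units; within the scatter). Combining both gave no change at the digits printed from compound 2 to compound 3 (within the scatter). Every variation of this group so far has stayed within the scatter, so no step beyond the scatter is expected from the methyl group either.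

For compound 4 in this assay the expected value is 0.27 nM, with a range of 0.13 nM to 0.55 nM. The step of no change at the digits printed from compound 2 to compound 4 (within the scatter) is thus estimated to lie within the scatter.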

Compound 4, inhibition constant: 0.92 nM
Beside the measured number, compound 4's estimate is 3.4-fold (0.53 log units) below it, outside the stated range (above it).
By their numbers in this assay, from the lowest: compounds 1, 2 and 3 (each within the scatter of the next); then compound 4.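

In this assay, a substituent on the pyrimidin-2-yl ring now moves the number beyond the scatter: methyl in place of hydrogen on an aromatic carbon gives a step (a 3.5-fold higher number from compound 1 to compound 4 (0.55 log units; beyond the scatter)). This change is not simply a matter of a group being present, since dimethylamino stayed within the scatter of hydrogen on that carbon, while methyl separates from dimethylamino (a 3.4-fold higher number from compound 3 to compound 4 (0.53 log units; beyond the scatter)) and 4-methylpyrimidin-2-yl separates from pyrimidin-4-yl (a 3.4-fold higher number from compound 2 to compound 4 (0.53 log units; beyond the scatter)). No measurement shown here accounts for the difference between the methyl and dimethylamino groups.

For the compounds shown here, compound 4 stands alone as the only evidence for this shift, so it remains open whether ethyl, methoxy or chlorine on the same aromatic carbon would follow methyl or dimethylamino. Also open, from the compounds shown here alone, is whether an amino or a methylamino group would stay within the scatter, as dimethylamino does.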